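A few compounds are considered here, and "the series" means these few. Any claim that something is new, unique, unknown or untested is made for them only; others in the source may bear on it.

Compound 1 `O=C(c1ccc(OCCCN2CC[C@H](NS(=O)(=O)c3ccc(Br)cc3)C2)cc1)C1CC1` gives 290 nM in an assay on isolated protein for binding affinity to histamine H2 receptor (Homo sapiens) (on this read-out higher numbers stand for weaker inhibition and lower numbers for stronger inhibition), the lowest of the three numbers in hand. Compound 3 `CC(=O)c1ccc(OCCCN2CC[C@H](NC(=O)c3cccnc3)C2)cc1` gives 3500 nM, and compound 2 `CC(=O)c1ccc(OCCCN2CC[C@H](NC(=O)[C@@H](N)CO)C2)cc1` gives 22000 nM. For the measured compounds named here, the one measured step, a 6.3-fold lower number from compound 2 to compound 3 (0.80 log units; beyond the scatter), concerns the group on the carbonyl carbon and does not touch the (4-bromophenyl)sulfonyl group. Compound 4 `Cc1ccc(S(=O)(=O)N[C@H]2CCN(CCCOc3ccc(C(=O)C4CC4)cc3)C2)cc1` differs from compound 1 by methyl in place of bromo on an aromatic carbon. Going by the values given here, no measured pair isolates this change; the (4-bromophenyl)sulfonyl group of compound 1 is otherwise untested in this set. The expectation for compound 4 is therefore a step of a 1.4-fold higher number from compound 1 to compound 4 (0.14 log units; within the scatter), not beyond the scatter in either direction. Compound 4 is estimated at 400 nM, with a range from 150 nM to 1100 nM.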

Compound 4, inhibition constant: 380 nM
Estimate against measurement, compound 4: 1.1-fold (0.02 log units) above; the range from low to high includes it.
By their numbers in this assay, from the lowest: compounds 1 and 4 (each within the scatter of the next); then compound 3; then compound 2.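

In this assay, the first direct test of this carbon, methyl in place of bromo para to a large group gives a 1.3-fold higher number from compound 1 to compound 4 (0.12 log units; within the scatter) and so shows no readable difference between these two groups. Within this pair, the bromine atom is therefore not required for a number of this size. Nothing available bears on why the exchange leaves the number within the scatter. Going by these compounds, whether a carboxylic acid, an amine or a longer chain at this carbon would keep the number near those of compound 1 and compound 4 remains open. Also open, on these data alone, is how a sulfonyl link compares with a carbonyl link on an otherwise identical compound.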